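The compounds below may be only part of what the source reports. "The series", "measured", "known", "first", "only" and "open" are said of these compounds alone.

Of the compounds shown here, three built on one shared core have been measured in an assay on MCF7 cells for inhibition of Serine-protein kinase ATM (Homo sapiens), read by immunofluorescence, with a stated time of 1 h; a lower number here means a stronger inhibitor, a higher number a weaker inhibitor. Compound 1 `COc1cc2ncnc(-n3nc(-c4ccccn4)nc3N)c2cc1OCCCNC(=O)CN1C[C@@H](C)O[C@@H](C)C1` gives 1700 nM. Compound 2 `COc1cc2ncnc(-n3nc(-c4ccccn4)nc3N)c2cc1OCCCNC(=O)OC(C)C` gives 1000 nM. Compound 3 `COc1cc2ncnc(-n3nc(-c4ccccn4)nc3N)c2cc1OCCCNC(=O)OCC(F)(F)F` gives 1200 nM, the second highest of the three numbers, with both neighbours close: a 1.2-fold higher number from compound 2 to compound 3 (0.08 log units; within the scatter) and a 1.4-fold lower number from compound 1 to compound 3 (0.15 log units; within the scatter). Compound 4 `CCCCCCOC(=O)NCCCOc1cc2c(-n3nc(-c4ccccn4)nc3N)ncnc2cc1OC` is not yet measured; it differs from compound 3 by pentyl in place of trifluoromethyl on a saturated chain carbon bound to an oxygen next to a carbonyl group. The measured exchange at the same place, a 1.2-fold higher number from compound 2 to compound 3 (0.08 log units; within the scatter), stayed within the scatter, as did a 1.7-fold lower number from compound 1 to compound 2 (0.23 log units; within the scatter). Since each change at this end of the chain has left the number essentially unchanged, compound 4 is expected to show no step beyond the scatter in this assay, a 1.1-fold higher number from compound 3 to compound 4 (0.03 log units; within the scatter). Compound 4 is therefore estimated at 1300 nM, within 600 nM to 3000 nM.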

Compound 4, half-maximal inhibitory concentration in the Serine-protein kinase ATM assay: 28600 nM
Estimate against measurement, compound 4: 22-fold (1.34 log units) below; measured number above the stated range.
By their numbers in the Serine-protein kinase ATM assay, from the lowest: compounds 2, 3 and 1 (each within the scatter of the next); then compound 4.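

In the Serine-protein kinase ATM assay, this end of the chain turns out not to be indifferent to change: hexyl brings a 24-fold higher number from compound 3 to compound 4 (1.38 log units; beyond the scatter), and the comparisons with the other two compounds agree, with a 29-fold higher number from compound 2 to compound 4 (1.46 log units; beyond the scatter) and a 17-fold higher number from compound 1 to compound 4 (1.23 log units; beyond the scatter). The smaller groups at this place showed no such sensitivity, so the tolerance they suggested does not extend to hexyl. In a physicochemical assay for solubility, in phosphate buffer, with a stated time of 18 h, at pH 7.4 (on this read-out lower numbers stand for lower solubility and higher numbers for higher solubility), compound 3 gives 100 nM and compound 4 gives 1000 nM. Poorer solubility cannot account for the loss, because compound 4 is the more soluble of the pair: the measured solubility of compound 3, 100 nM, and of compound 4, 1000 nM, a 10-fold higher number (1.00 log units; beyond the scatter)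

Still open, going by these compounds, is where between 2,2,2-trifluoroethyl and hexyl the loss sets in, and whether length alone drives it. A butyl chain or a benzyl group on the same oxygen would help settle both.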